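This account rests on a few compounds, and the source may have more. Where it says the series, first, only, none or still open, it means among the compounds named here.

Working notes on the series. Compound 1 `COc1ccc(-c2cc3cc(C4C(C#N)=C(N)OC5=C4C(=O)CC(C)(C)C5)cc(C(C)C)c3oc2=O)cc1` and compound 3 `COc1ccc(-c2cc3cc(C4C(C#N)=C(N)OC5=C4C(=O)CC(C)(C)C5)cc(C(C)C)c3oc2=O)cc1OC` share one core, and the change between them is methoxy in place of hydrogen on an aromatic carbon. In a functional assay on the whole organism (strain Swiss albino) with Mus musculus as the target, in the forced swim test, with a stated time of 5 min, at a dose of 0.5 mg/kg by the intraperitoneal route (a lower number here means less inhibition, a higher number more inhibition at the dose given (going by the name of the read-out)), compound 1 gives 64.9%, while compound 3 gives 86.6%; the step is a number 21.7 percentage points higher from compound 1 to compound 3 (beyond the scatter). Compound 2 `COc1ccc(-c2cc3cc(C4C(C#N)=C(N)OC5=C4C(=O)CCC5)cc(C(C)C)c3oc2=O)cc1OC` carries a different core, and the difference between the two cores is not broken down here; in this assay compound 2 gives 57.2%, which stands within the scatter of compound 1 and beyond it against compound 3.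

Compound 4 `COc1cc(-c2cc3cc(C4C(C#N)=C(N)OC5=C4C(=O)CCC5)cc(C(C)C)c3oc2=O)cc(OC)c1OC` has not been measured. It differs from compound 2 by methoxy in place of hydrogen on an aromatic carbon. Within the data shown here, this is the same kind of change as the one from compound 1 to compound 3, with one difference in its surroundings: the entering methoxy in compound 4 is ortho to a methoxy group, meta to a large group and also meta to a methoxy group, whereas in compound 3 it is ortho to a methoxy group and meta to a large group only.

In this assay, among the measured compounds shown here, a step of similar direction is expected from compound 2, namely a number 14.8 percentage points higher from compound 2 to compound 4 (beyond the scatter), because a number 21.7 percentage points higher from compound 1 to compound 3 (beyond the scatter) was the size of the one step of this kind seen so far; with a different core and a further methoxy group around the place, the estimate is kept wide. For compound 4 the expected value is 72%, with a range from 55% to 88%.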

Compound 4, a percentage reported as inhibition, in the whole organism at one dose (the size of the read-out at that dose, not a potency): 31.9%
Compound 4: middle estimate off by 40.1 percentage points, on the high side; measured number below the stated range.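

In this assay, methoxy in place of hydrogen on an aromatic carbon does not keep its direction from one core to the other: the new step is a number 25.3 percentage points lower from compound 2 to compound 4 (beyond the scatter), and the two steps set side by side read: the same change on two cores in this assay, a number 21.7 percentage points higher (beyond the scatter) from compound 1 to compound 3 and a number 25.3 percentage points lower (beyond the scatter) from compound 2 to compound 4, 47 percentage points apart, beyond the scatter of two such steps

The two steps differ in more than the core, since the methoxy entering compound 4 is also meta to a methoxy group, a surrounding that the methoxy entering compound 3 does not have. With one step on each core, these notes cannot say whether the core, the added methoxy neighbour or both go with the reversal, and they give no rule for this change on either core.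

The compounds shown leave open how a 3,4,5-trimethoxyphenyl group reads on the core of compound 1, a comparison that would separate the core from the surroundings of the entering group. Also open, going by these compounds, is how an amine, a hydroxyl group or a longer chain such as ethoxy would read on that aromatic carbon in this assay, on either core.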